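A thiol replaces the hydroxyethylamino chain on the shared core

The source may report more compounds than this note shows. Statements on the series, on what has been measured and on what is new or still open speak of the compounds shown alone.

Compound 1, `OC[C@H]1OC(n2cnc3c(S)nccc32)[C@H](O)[C@@H]1O`: 9 mg/kg
Compound 2, `CCCCCCNc1[nH]ccc2ncnc1-2`: > 9 mg/kg, a limit of the assay
Compound 3, `OCCNc1[nH]ccc2ncnc1-2`: > 9 mg/kg, a limit of the assay

Of the compounds shown here, three have been tested in a functional assay on the whole organism (Pleural cavity) with Rattus norvegicus as the target; a higher number here means that more compound is needed for the effect, a lower number that less compound is needed. For the measured compounds named here, compound 1 gives 9 mg/kg, the only value reported as a number. Compound 2 reaches only the limit > 9 mg/kg. Compound 3 likewise stops at the limit > 9 mg/kg, so its place on the scale is known only as a bound, not as a number. Going by the values given here, the one measured step, a step that the two limits leave unreadable from compound 2 to compound 3, is therefore unreadable, and the limit of > 9 mg/kg in this assay, at which 2 of the 3 values shown sit, is the single piece of evidence the data offer.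

Compound 4, `Sc1[nH]ccc2ncnc1-2`, has not yet been measured. It differs from compound 3 in one place: sulfanyl in place of (2-hydroxyethyl)amino on an aromatic carbon. The (2-hydroxyethyl)amino group leaves and a sulfanyl group enters on the aromatic carbon described above. Among the compounds with values here, no measured step covers this change, and the one step that exists is unreadable, so no direction can be read from the data.

With compound 3 sitting at a limit, the expected result for compound 4 is 15 mg/kg, within 5 mg/kg to 50 mg/kg. The expected step that the limit leaves unreadable from compound 3 to compound 4 is accordingly no more than the scatter, with a fair chance that only a limit is reported again.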

Compound 4, dose for half-maximal effect: 8 mg/kg
Compound 4: the middle estimate sits 1.9-fold (0.27 log units) above what was measured; low and high end bracket the measured number.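

For the compounds shown here, on the shared core, a sulfanyl group on this aromatic carbon, next to the ring nitrogen, yields the first number for a compound without the sugar-like ring of compound 1: in this assay compound 4 gives 8 mg/kg. Compound 2 and compound 3 stopped at limits of the assay. Exchanging the (2-hydroxyethyl)amino group and its 4 heavy atoms for sulfanyl, with its 1 heavy atom, gives an at least 1.1-fold lower number from compound 3 to compound 4 (0.05 log units; that floor lies within the scatter), so the long-looking change in this group is not shown to matter beyond ordinary variation between repeated measurements. The true size of this step cannot be read, and neither can the earlier step between the two chain compounds, because both rest on a limit rather than a number: the limit of > 9 mg/kg in this assay, at which 2 of the 4 values shown sit.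

As far as these compounds go, whether compound 4 truly needs less compound than compound 3 therefore stays open, as a real difference could be large or could vanish within the scatter. Also open, from the compounds shown here alone, is how a plain amino group, a hydroxy group or a methylsulfanyl group on the same aromatic carbon would compare with sulfanyl, which would show whether the sulfur atom itself is what counts here.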